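Swapping the aryl group on the pyrazole of compound 3

This account rests on a few compounds, and the source may have more. Where it says the series, first, only, none or still open, it means among the compounds named here.

Of the compounds shown here, three sharing one core have been tested in a functional assay on BJAB cells (Homo sapiens) for antiproliferative activity, with a stated time of 4 days; on this read-out lower numbers stand for an effect already at smaller amounts and higher numbers for an effect only at larger amounts of compound. Compound 1 `Cc1c(-c2cc(Cl)cc(Cl)c2)c(C(=O)O)nn1-c1nc(-c2cccnc2)c(SC(C)C)s1` gives "not active" (no number reported) in this assay, with no number to place it. Compound 2 `Cc1nn(-c2nc(-c3ccc(Cl)c(Cl)c3)c(SC(C)C)s2)c(C(=O)O)c1-c1cccc(F)c1` gives 900 nM in this assay. For the measured compounds named here, compound 3 `COc1cncc(-c2c(C)nn(-c3nc(-c4ccc(Cl)c(Cl)c4)c(SC(C)C)s3)c2C(=O)O)c1` gives 21000 nM in this assay, the highest of the two numbers that exist; the only step connecting them, a 23-fold higher number from compound 2 to compound 3 (1.37 log units; beyond the scatter), shows that exchanging one aryl group at this position for another moved the read-out by a large amount.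

Compound 4 `Cc1nn(-c2nc(-c3ccc(Cl)c(Cl)c3)c(SC(C)C)s2)c(C(=O)O)c1-c1cnccn1` is the next exchange at the same place: pyrazin-2-yl in place of 5-methoxypyridin-3-yl on an aromatic carbon. Going by the values given here, only one measured step bears on it, the large one from compound 2 to compound 3, and it shows that this position is sensitive. With no measured pyrazine to guide the direction, the expectation for compound 4 is a number close to compound 3, a step of a 1.4-fold lower number from compound 3 to compound 4 (0.15 log units; within the scatter) that may stay within the scatter. Compound 4 is therefore estimated at 15000 nM in this assay, within a range from 4000 nM to 60000 nM.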

Compound 4, half-maximal effective concentration: 14000 nM
Compound 4: middle estimate off by 1.1-fold (0.03 log units), on the high side; the measured number falls inside the stated range.
By their numbers in this assay, from the lowest: compound 2; then compounds 4 and 3 (each within the scatter of the next).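

In this assay, putting pyrazin-2-yl in place of 5-methoxypyridin-3-yl gives a 1.5-fold lower number from compound 3 to compound 4 (0.18 log units; within the scatter), so the two groups cannot be told apart here, even though they differ in size and in the number of hetero atoms in the ring. Replacing 3-fluorophenyl with pyrazin-2-yl gives a 16-fold higher number from compound 2 to compound 4 (1.19 log units; beyond the scatter), which means that both nitrogen-containing rings shown at this place give numbers well above the number of compound 2, not just the methoxy-bearing one. The data offered here include no measurement that explains this gap.

On these data alone, it remains open whether the gap follows the ring nitrogen or the loss of the fluorine. A plain phenyl ring or an unsubstituted pyridin-3-yl at this place would help separate those two readings.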